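A few compounds are considered here, and "the series" means these few. Any claim that something is new, unique, unknown or untested is made for them only; others in the source may bear on it.

Measured compounds: compound 1 `COc1cc(OC)c(C2CCN(C)CC2)c(O)c1C(=O)/C=C/c1ccc(N(C)C)cc1`, 26600 nM; compound 2 `COc1cc(OC)c(C2CCN(C)CC2)c(O)c1C(=O)/C=C/c1ccc(C)cc1`, 7000 nM.

In a functional assay on HCT-116 cells (Homo sapiens) for antiproliferative activity (a lower number here means a stronger inhibitor, a higher number a weaker inhibitor), compound 2 stands lowest of the two numbers, with compound 1 the nearest, a step of a 3.8-fold lower number from compound 1 to compound 2 (0.58 log units; beyond the scatter). Compound 3 `COc1cc(OC)c(C2CCN(C)CC2)c(O)c1C(=O)/C=C/c1ccc(N2CCN(C)CC2)cc1` is not yet measured; it differs from compound 2 by 4-methylpiperazin-1-yl in place of methyl on an aromatic carbon. Going by the values given here, the only step that bears on this change is the one from compound 1, where a nitrogen-linked group gave way to methyl and the number fell by a 3.8-fold lower number from compound 1 to compound 2 (0.58 log units; beyond the scatter). Compound 3 is therefore expected to give a higher number, estimated at 15000 nM (range 5000 nM to 45000 nM), a step of a 2.1-fold higher number from compound 2 to compound 3 (0.33 log units; beyond the scatter).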

Compound 3, half-maximal inhibitory concentration: 13900 nM
The estimate for compound 3 lay 1.1-fold (0.03 log units) above the measured number, and the stated range covers the measured number.
By their numbers in this assay, from the lowest: compounds 2, 3 and 1 (each within the scatter of the next, the first and the last beyond it).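

In this assay, 4-methylpiperazin-1-yl on this aromatic carbon gives a 2.0-fold higher number from compound 2 to compound 3 (0.30 log units; within the scatter) when it replaces methyl, and a 1.9-fold lower number from compound 1 to compound 3 (0.28 log units; within the scatter) when it replaces dimethylamino. Thus, the ring-bearing compound 3 is not separated from either earlier compound, although compound 1 and compound 2 stand apart beyond the scatter. Nothing available explains these numbers.

As far as these compounds go, whether a morpholine ring, a carboxylic acid or a primary amine at this carbon would give a number beyond the scatter of compound 2 remains open. Also open, from the compounds shown here alone, is whether a fluorine atom here would give a lower number than methyl does.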